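A few compounds are considered here, and "the series" means these few. Any claim that something is new, unique, unknown or untested is made for them only; others in the source may bear on it.

The measured compounds:
compound 1, `Cc1cccc(NC(=O)N[C@@H](C)c2ccccc2)c1`, 100%;
compound 2, `CCc1cccc(NC(=O)N[C@@H](C)c2ccccc2)c1`, 86%;
compound 3, `CCCCCc1ccc(NC(=O)N[C@H](C)c2ccccc2)cc1`, 97%.

In an ADME assay on the whole organism with Oryza sativa as the target, tested at 10 uM (on this read-out higher numbers stand for a weaker effect at the one concentration tested and lower numbers for a stronger effect), compound 1 gives 100%. The change from compound 1 to compound 2 is methyl in place of hydrogen on a saturated chain carbon bound to an aromatic carbon, and it made a number 14 percentage points lower from compound 1 to compound 2 (beyond the scatter). Compound 3 stands close to compound 1, and its difference from compound 2 lies beyond the scatter; the difference between the core of compound 3 and the core of compound 1 is not broken down here.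

Compound 4, `CCCCCCc1ccc(NC(=O)N[C@H](C)c2ccccc2)cc1`, is not yet measured. It differs from compound 3 by methyl in place of hydrogen on a saturated chain carbon, five bonds along the chain from an aromatic carbon. Within the data shown here, this is the same kind of change as the one from compound 1 to compound 2, but not the same: there the place was on a saturated chain carbon bound to an aromatic carbon, here it is five bonds along the chain from an aromatic carbon.

On that single earlier step, compound 4 is expected to give 90% in this assay. The expected step is a number 7 percentage points lower from compound 3 to compound 4 (within the scatter), smaller than the earlier one because the place differs and because a number 14 percentage points lower from compound 1 to compound 2 (beyond the scatter) rests on one pair alone.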

Compound 4, a percentage reported as activity, at one concentration (the size of the read-out at that concentration, not a potency): 101%
For compound 4 the middle estimate is 11 percentage points below the measured one; measured number above the stated range.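

In this assay, methyl in place of hydrogen on a saturated chain carbon, five bonds along the chain from an aromatic carbon, gives a number 4 percentage points higher from compound 3 to compound 4 (within the scatter). Set beside the earlier step, this shows that the change did not carry over as a fixed step from one core to the other in this series: the same change on two cores in this assay, a number 14 percentage points lower (beyond the scatter) from compound 1 to compound 2 and a number 4 percentage points higher (within the scatter) from compound 3 to compound 4, 18 percentage points apart, beyond the scatter of two such steps It does not show what separates the two results, as the pairs differ in the place of the change as well as in the core, and a single pair on each side cannot tell these two differences apart.

The compounds shown leave open whether the same change at one shared place would give matching steps on the core of compound 1 and the core of compound 3. They also leave open whether a longer chain, or an amine or a carboxylic acid in place of the chain, would give a number beyond the scatter of compound 4.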